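A few compounds are considered here, and "the series" means these few. Any claim that something is new, unique, unknown or untested is made for them only; others in the source may bear on it.

The three measured compounds share one core and differ only in the ring attached to the amide-type nitrogen. Compound 1 `O=C(CSc1snnc1-c1ccc(Br)cc1Br)Nc1ccccc1F` carries a 2-fluorophenyl there. In an ADME assay on MT4 cells (Homo sapiens) for cytotoxicity, read by MTT assay, with a stated time of 5 days (a higher number here means that more compound is tolerated, a lower number that less compound is tolerated), compound 1 gives >= 27800 nM, which is a limit of the measurement rather than a number. Compound 2 `Cc1cccc(C)c1NC(=O)CSc1snnc1-c1ccc(Br)cc1Br` carries a 2,6-dimethylphenyl. In this assay compound 2 gives >= 198000 nM, again a limit. Compound 3 `Cc1ccccc1NC(=O)CSc1snnc1-c1ccc(Br)cc1Br` carries a 2-methylphenyl, and in this assay compound 3 gives 202000 nM. The steps a step that the two limits leave unreadable from compound 1 to compound 2, a step that the limit leaves unreadable from compound 1 to compound 3 and a step that the limit leaves unreadable from compound 2 to compound 3 are left unreadable by those limits. What can be said is that every value sits high: one at the limit of >= 27800 nM in this assay, at which 1 of the 3 values shown sits, one at the limit of >= 198000 nM in this assay, at which 1 of the 3 values shown sits, and compound 3 close to the latter. Compound 4 `O=C(CSc1snnc1-c1ccc(Br)cc1Br)Nc1ccc(Cl)cc1` is not yet measured. It differs from compound 1 by 4-chlorophenyl in place of 2-fluorophenyl on an amide-type nitrogen. No readable step bears on this change, so the expectation rests only on the uniformly high tolerance seen so far. Compound 4 is therefore estimated to be tolerated at 150000 nM, within a range from 30000 nM to 300000 nM. This expected outcome corresponds to a step that the limit leaves unreadable from compound 1 to compound 4, and a limit rather than a number would not be surprising.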

Compound 4, half-maximal cytotoxic concentration: 23300 nM
The estimate for compound 4 lay 6.4-fold (0.81 log units) above the measured number, outside the stated range (below it).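

The result gives the first clear separation in this series: 4-chlorophenyl in place of 2-methylphenyl on the amide-type nitrogen brings an 8.7-fold lower number from compound 3 to compound 4 (0.94 log units; beyond the scatter) in this assay, so the group at this position can change how much compound is tolerated. Replacing 2,6-dimethylphenyl gives an at least 8.4-fold lower number from compound 2 to compound 4 (0.92 log units; beyond the scatter), a size that rests on a limit rather than a number: the limit of >= 198000 nM in this assay, at which 1 of the 4 values shown sits. Replacing 2-fluorophenyl gives an at least 1.1-fold lower number from compound 1 to compound 4 (0.07 log units; that floor lies within the scatter), so these two groups are not told apart, and this step also rests on a limit: the limit of >= 27800 nM in this assay, at which 1 of the 4 values shown sits.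

On these data alone, whether the lower number goes with the chlorine itself or with where it sits on the ring stays open, and 2-chlorophenyl and 4-methylphenyl on the same nitrogen would help separate the two. Also open, as far as these compounds go, is how a phenyl ring carrying an amine or a carboxylic acid would behave at this position.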